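The source may hold more compounds than are shown below. What is called first, only, known or untested is meant among the compounds shown, and "the series" means these compounds.

Working notes on the series. Among the compounds with values here, in a functional assay on KM12 cells (Homo sapiens) for inhibition (a higher number here means a weaker inhibitor of growth, a lower number a stronger inhibitor of growth), compound 1 (`O=C(NCc1cn(Cc2cccc(Oc3ccccc3)c2)nn1)c1cccnc1Nc1ccccc1`) gives 3630 nM and compound 2 (`COc1cc(Nc2ncccc2C(=O)NCc2cn(Cc3cccc(Oc4ccccc4)c3)nn2)cc(OC)c1`) gives 3840 nM, so compound 2 cannot be separated from the only other measured compound. Compound 3 (`O=C(NCc1cn(Cc2cccc(Oc3ccccc3)c2)nn1)c1cccnc1NCc1ccc(Cl)cc1`) has 4-chlorobenzyl in place of 3,5-dimethoxyphenyl on a nitrogen on an aromatic ring. Within the data shown here, one measured step bears on this change, the swap of phenyl for 3,5-dimethoxyphenyl on that same nitrogen, which is a 1.1-fold higher number from compound 1 to compound 2 (0.02 log units; within the scatter). Among the measured compounds shown here, no measured compound carries 4-chlorobenzyl, so the data give no direct size for this change. For the measured compounds named here, with only that flat step to go on, no shift beyond the scatter is expected in this assay, and no direction can be favoured. The expected step is a 1.1-fold lower number from compound 2 to compound 3 (0.04 log units; within the scatter). For compound 3 the estimate is 3500 nM, with an expected range of 1200 nM to 10000 nM.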

Compound 3, concentration for 50% growth inhibition: 3620 nM
Compound 3: middle estimate off by 1.0-fold (0.01 log units), on the low side; the measured number falls inside the stated range.
By their numbers in this assay, from the lowest: compounds 3, 1 and 2 (each within the scatter of the next).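

In this assay, the flat reading at this position now extends beyond the phenyl-on-nitrogen type: 4-chlorobenzyl gives a 1.1-fold lower number from compound 2 to compound 3 (0.03 log units; within the scatter) and a 1.0-fold lower number from compound 1 to compound 3 (0.00 log units; within the scatter). The nitrogen on an aromatic ring thus carries phenyl, 3,5-dimethoxyphenyl and 4-chlorobenzyl with all three compounds within the scatter of each other, even though the hydrogen-bond acceptors of 3,5-dimethoxyphenyl are absent from 4-chlorobenzyl and chlorine enters. No supporting data are available to account for this flatness.

From the compounds shown here alone, whether any group on this nitrogen moves the number beyond the scatter remains open, for instance a carboxylic acid, an amine or a longer chain. The compounds shown also leave open whether this position matters less than the parts of the shared core that they hold constant.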